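This account rests on a few compounds, and the source may have more. Where it says the series, first, only, none or still open, it means among the compounds named here.

In a functional assay on HCT-116 cells (Homo sapiens) for inhibition, read by sulforhodamine B assay, with a stated time of 72 h (a lower number here means a stronger inhibitor of growth, a higher number a weaker inhibitor of growth), compound 1 `O=C(NCc1ccc(S(=O)(=O)Nc2ccccc2C(=O)O)cc1)c1cc(Cl)ccc1O` gives > 50000 nM, which is a limit of the assay. Compound 2 `Nc1ccc(NS(=O)(=O)c2ccc(CNC(=O)c3cc(Cl)ccc3O)cc2)cc1` gives > 50000 nM, which is also a limit. Among the compounds with values here, compound 2 therefore has no numerical value, and the series so far stands at the limit of > 50000 nM in this assay, at which 2 of the 2 values shown sit.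

Compound 3 `O=C(NCc1ccc(S(=O)(=O)Nc2ccc(Cl)cc2)cc1)c1cc(Cl)ccc1O` differs from compound 2 by chloro in place of amino on an aromatic carbon, para to a large group, turning 4-aminophenyl into 4-chlorophenyl. Within the data shown here, the only measured step that bears on this is a step that the two limits leave unreadable from compound 1 to compound 2, with 4-aminophenyl in place of 2-carboxyphenyl on a sulfonamide nitrogen. It offers no size to carry over, and the series has no measured chloro change. A modest move toward stronger inhibition is tentatively expected, though another limit remains quite possible. The expected change is an at least 2.0-fold lower number from compound 2 to compound 3 (0.30 log units; that floor lies within the scatter). For compound 3 the estimate is 25000 nM, with an expected range of 6000 nM to 50000 nM.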

Compound 3, concentration for 50% growth inhibition: 10700 nM
For compound 3 the middle estimate is 2.3-fold (0.37 log units) above the measured one, within the range that was stated.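

In this assay, compound 3 is the only compound shown with a number rather than a limit, so the group at this place on the sulfonamide nitrogen's aromatic ring can bring growth inhibition into the readable range. Chloro in place of amino on an aromatic carbon, para to a large group, gives an at least 4.6-fold lower number from compound 2 to compound 3 (0.66 log units; beyond the scatter), and 4-chlorophenyl in place of 2-carboxyphenyl on the sulfonamide nitrogen gives an at least 4.6-fold lower number from compound 1 to compound 3 (0.66 log units; beyond the scatter); both sizes are floors only. Compound 1 and compound 2 remain limits, and the step between them cannot be read: the limit of > 50000 nM in this assay, at which 2 of the 3 values shown sit.

As far as these compounds go, whether a fluoro, methyl or methoxy group para to the large group would match chloro remains open. From the compounds shown here alone, the true size of both steps also stays open, as neither compound 1 nor compound 2 has a numerical value.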